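A few compounds are considered here, and "the series" means these few. Any claim that something is new, unique, unknown or untested is made for them only; others in the source may bear on it.

Compound 1 `O=C1NC(=S)S/C1=C\C=C\c1ccccc1OS(=O)(=O)c1ccccc1` gives 80% in a functional assay on DLD-1 cells (Homo sapiens), read by microscopy and crystal violet staining, with a stated time of 20 h, tested at 10 ug/mL; a lower number here means less inhibition, a higher number more inhibition at the concentration tested (going by the name of the read-out).
Compound 2 `COc1cccc(COc2ccccc2/C=C/C=C2\SC(=S)NC2=O)c1` gives 82% in this assay.

Of the two measured compounds, compound 2 stands alongside compound 1, the two numbers lying within the usual scatter of each other, so no order between them can be claimed. Compound 3 `COc1ccccc1/C=C/C=C1\SC(=S)NC1=O` has not been measured. It differs from compound 2 by hydrogen in place of 3-methoxyphenyl on a saturated chain carbon bound to an oxygen on an aromatic ring. Within the data shown here, no measured pair shows this change, so its effect in this assay is unknown; a loss of inhibition beyond the scatter is expected, and the step of a number 22 percentage points lower from compound 2 to compound 3 (beyond the scatter) is an estimate. Compound 3 is therefore expected to give about 60%, with a range from 25% to 90%.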

Compound 3, a percentage reported as inhibition, at one concentration (the size of the read-out at that concentration, not a potency): 69%
Compound 3: the middle estimate sits 9 percentage points below what was measured; the measured number falls inside the stated range.
By their numbers in this assay, from the lowest: compound 3; then compounds 1 and 2 (each within the scatter of the next).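

Hydrogen in place of 3-methoxyphenyl on a saturated chain carbon bound to an oxygen on an aromatic ring gives a number 13 percentage points lower from compound 2 to compound 3 (beyond the scatter) in this assay, so this change does lower inhibition at this position. The loss is only partial, as compound 3 still gives 69% at the concentration tested, without the 3-methoxyphenyl. No measurement on these compounds accounts for the loss.

The compounds shown leave open whether a plain phenyl or a morpholine on that carbon would restore the inhibition seen with compound 2. They also leave open whether a pyridine ring would do the same.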